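Pyridinylmethyl in Place of Cyclohexylmethyl on the Aminopyrimidine Core

A few compounds are considered here, and "the series" means these few. Any claim that something is new, unique, unknown or untested is made for them only; others in the source may bear on it.

Compound 2 `CNc1nc(NCC2CCCCC2)cc(-c2ccccn2)n1` gives the lowest number of the two compounds measured in a functional assay on HEK293 cells for agonist activity at G-protein coupled receptor 39 (Mus musculus), read by inositol phosphate accumulation; on this read-out lower numbers stand for an effect already at smaller amounts and higher numbers for an effect only at larger amounts of compound. Its nearest neighbour is compound 1 `CNc1nc(NCC(C)(C)C)cc(-c2ccccn2)n1`, which in this assay gives 365 nM, whereas compound 2 gives 10 nM. Going by the values given here, the only step known so far, a 37-fold lower number from compound 1 to compound 2 (1.56 log units; beyond the scatter), shows that the group on the saturated chain carbon bound to the ring nitrogen has a strong influence on the read-out.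

Compound 3 `CNc1nc(NCc2ccncc2)cc(-c2ccccn2)n1` has not yet been measured. It differs from compound 2 in one place: pyridin-4-yl in place of cyclohexyl on a saturated chain carbon bound to a nitrogen on an aromatic ring. Among the compounds with values here, no measured pair covers an exchange of a saturated carbon ring for an aromatic ring with one hetero atom at this position; the step from compound 1 to compound 2 only shows that a change at this position can move the number a great deal. The entering group is of the same size but otherwise unlike the one that leaves, so for compound 3 a change beyond the scatter toward a higher number is expected, estimated as a 6.0-fold higher number from compound 2 to compound 3 (0.78 log units; beyond the scatter), with wide uncertainty. The estimate for compound 3 in this assay is therefore 60 nM, with a range from 15 nM to 300 nM.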

Compound 3, half-maximal effective concentration: 304 nM
Compound 3: middle estimate off by 5.1-fold (0.70 log units), on the low side, outside the stated range (above it).
By their numbers in this assay, from the lowest: compound 2; then compounds 3 and 1 (each within the scatter of the next).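

In this assay, pyridin-4-yl in place of cyclohexyl on a saturated chain carbon bound to a nitrogen on an aromatic ring gives a 30-fold higher number from compound 2 to compound 3 (1.48 log units; beyond the scatter), so matching the heavy-atom count of cyclohexyl does not preserve the low number of compound 2. Pyridin-4-yl in place of tert-butyl gives a 1.2-fold lower number from compound 1 to compound 3 (0.08 log units; within the scatter), which leaves compound 1 and compound 3 indistinguishable here, while compound 2 is set apart from each of them by a step beyond the scatter. Nothing in hand accounts for this difference between the groups.

The compounds shown do not separate the effect of aromaticity from that of the ring nitrogen: phenyl would have an aromatic ring with no nitrogen, and piperidin-4-yl would place a nitrogen in a saturated ring, but neither group is among them. They also leave open whether pyridin-3-yl or pyridin-2-yl at this position would give a number like that of compound 3 or one closer to that of compound 2.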